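Thiocarbonyl ring change from compound 2 to compound 3

The source may hold more compounds than are shown below. What is called first, only, known or untested is meant among the compounds shown, and "the series" means these compounds.

For the measured compounds named here, in a functional assay on HCT-116 cells (Homo sapiens) for inhibition, read by CCK-8 assay, with a stated time of 48 h (on this read-out higher numbers stand for weaker inhibition and lower numbers for stronger inhibition), compound 2 `COc1ccc(CN(C(=O)CSC(=S)N2CCN(C(C)=O)CC2)c2cc(OC)c(OC)c(OC)c2)cc1` gives 1370 nM and holds the lower of the two numbers so far, while compound 1 `COc1ccc(CN(C(=O)CSc2nc3ccccc3o2)c2cc(OC)c(OC)c(OC)c2)cc1` gives 3280 nM and holds the higher. Going by the values given here, compound 3 `COc1ccc(CN(C(=O)CSC(=S)N2CCCC2)c2cc(OC)c(OC)c(OC)c2)cc1` has pyrrolidin-1-yl in place of 4-acetylpiperazin-1-yl on a thiocarbonyl carbon and has no measurement yet. Among the compounds with values here, the one measured step that bears on this is a 2.4-fold lower number from compound 1 to compound 2 (0.38 log units; beyond the scatter) and counts as modest, though beyond the scatter. Within the data shown here, that step replaced the whole group on a sulfur, and no measured pair varies only the ring on the thiocarbonyl carbon. It therefore sets a rough size and gives no direction, so no step beyond the scatter is the expectation in this assay here. The estimated step is a 1.1-fold higher number from compound 2 to compound 3 (0.04 log units; within the scatter) on present evidence. For compound 3 the expected value is 1500 nM with an estimated range from 550 nM to 4200 nM in this read-out.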

Compound 3, half-maximal inhibitory concentration: 4970 nM
For compound 3 the middle estimate is 3.3-fold (0.52 log units) below the measured one, and the stated range ends below it.
By their numbers in this assay, from the lowest: compound 2; then compounds 1 and 3 (each within the scatter of the next).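

In this assay, for the compounds shown here, the first change confined to the ring on the thiocarbonyl carbon shows that this position responds: pyrrolidin-1-yl in place of 4-acetylpiperazin-1-yl gives a 3.6-fold higher number from compound 2 to compound 3 (0.56 log units; beyond the scatter). The thiocarbonyl carbon alone therefore does not carry the lower number of compound 2, as replacing the whole group on the sulfur now gives a 1.5-fold higher number from compound 1 to compound 3 (0.18 log units; within the scatter), which leaves compound 1 and compound 3 within the scatter of each other. No measurement on hand offers an explanation for the step from the 4-acetylpiperazin-1-yl ring to the pyrrolidin-1-yl ring.

Ring size, the second ring nitrogen and the acetyl group all change together in this step, so their separate contributions remain open. Piperidin-1-yl, morpholin-4-yl and 4-methylpiperazin-1-yl on the thiocarbonyl carbon would each pull these features apart.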